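A Halogen Swap at the Phenoxy Tail

The source may hold more compounds than are shown below. What is called first, only, known or untested is meant among the compounds shown, and "the series" means these compounds.

The measured compounds:
compound 1, `CC(C)(C)c1ccc(OCCCON2C(N)=NC(N)=NC23CCSCC3)cc1`, which gives 85.3% in an assay on isolated protein for inhibition of Dihydrofolate reductase (Homo sapiens), read by spectrophotometry, using NADPH, with stated times of 5 s and 6 min, tested at 5 uM; on this read-out higher numbers stand for a stronger effect at the one concentration tested and lower numbers for a weaker effect
compound 2, `NC1=NC2(CCSCC2)N(OCCCOc2ccc(Br)cc2)C(N)=N1`, which gives > 90% in this assay
compound 3, `Cc1cc(C)cc(OCCCON2C(N)=NC(N)=NC23CCOCC3)c1`, which gives 84.3% in this assay

The reading for compound 2 is a limit of the assay rather than a number: compound 2 stands at the limit of > 90% in this assay, at which 1 of the 3 values shown sits. For the measured compounds named here, the single measured step that touches the tail of compound 2 is a number at least 4.7 percentage points higher from compound 1 to compound 2 (that floor lies within the scatter), so it sets only a floor and shows no movement beyond the scatter. Compound 1 and compound 3 differ in more than one place, and their two values lie close together.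

The next compound is compound 4, `NC1=NC2(CCSCC2)N(OCCCOc2ccccc2Cl)C(N)=N1`. It differs from compound 2 by 2-chlorophenyl in place of 4-bromophenyl on an oxygen on a saturated carbon. Because a number at least 4.7 percentage points higher from compound 1 to compound 2 (that floor lies within the scatter) stayed within the scatter when the tail was changed, no step beyond the scatter is expected here either, in either direction, and compound 4 is estimated to give about 83%, with a range from 66% to 92% in this assay. The step this estimate implies is expected to be a number at least 7 percentage points lower from compound 2 to compound 4 (that floor lies within the scatter).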

Compound 4, a percentage reported as inhibition, at one concentration (the size of the read-out at that concentration, not a potency): 86.3%
Compound 4: the middle estimate sits 3.3 percentage points below what was measured, within the range that was stated.
By their numbers in this assay, from the lowest: compounds 3, 1 and 4 (each within the scatter of the next). At a limit, above all of these: compound 2.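

In this assay, 2-chlorophenyl in place of 4-bromophenyl on an oxygen on a saturated carbon gives a number at least 3.7 percentage points lower from compound 2 to compound 4 (that floor lies within the scatter). For the compounds shown here, this swap changes both the halogen and its place on the phenyl ring, a different kind of change at the tail from the one in the earlier step, and its step still stays within the scatter. The reading for compound 2 is a limit of the assay, so this step too sets only a floor on the change: the limit of > 90% in this assay, at which 1 of the 4 values shown sits.

The compounds shown leave open how the halogen and its place on the ring each contribute, which a 4-chlorophenyl tail on the same core would begin to separate. They also leave open how the tail would read with an amine or a carboxylic acid on the ring, or with a longer chain before the phenoxy group.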